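The compounds below may be only part of what the source reports. "The series", "measured", "known", "first", "only" and "open" are said of these compounds alone.

Measured so far:
compound 1, `O=C(O)CCO/N=C/C1CCC1`: 16%
compound 2, `O=C(O)CCO/N=C/c1ccccc1`: 66%

Both numbers come from a functional assay on the whole organism for inhibition, with Rattus norvegicus as the target, with a stated time of 4 h, at a dose of 50 mg/kg by the intraperitoneal route; on this read-out higher numbers stand for more inhibition at the one dose given (going by the name of the read-out) and lower numbers for less inhibition. For the measured compounds named here, compound 2 stands highest of the two; its only neighbour is compound 1, whose value lies below it by a gap that exceeds the usual scatter. Going by the values given here, no two measured compounds differ in just one place, so no single structural step has yet been measured in this assay.

Compound 3, `O=C(O)CCO/N=C\c1ccccc1`, is still to be measured. Relative to compound 2 the change is: the two compounds have the same atoms and bonds and differ only in configuration as drawn: 1 of 1 stereo elements differ; a double bond is drawn E in compound 2 and Z in compound 3. The measured pair, compound 1 against compound 2, exchanges a ring and leaves the double bond drawn E in both, so nothing measured here speaks to a double bond drawn E against one drawn Z. The step in this assay is expected to be of modest size, more likely downward than upward, and it may well stay within the scatter. For compound 3 the expected value is 45%, with a range of 15% to 75%. That estimate amounts to an expected step of a number 21 percentage points lower from compound 2 to compound 3 (beyond the scatter).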

Compound 3, a percentage reported as inhibition, in the whole organism at one dose (the size of the read-out at that dose, not a potency): 0%
Beside the measured number, compound 3's estimate is 45 percentage points above it, and the stated range ends above it.
By their numbers in this assay, from the lowest: compound 3; then compound 1; then compound 2.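

In this assay, for the compounds shown here, turning the double bond from drawn E to drawn Z gives a number 66 percentage points lower from compound 2 to compound 3 (beyond the scatter), the only single-place step so far. Going by these compounds alone, with the atoms and bonds unchanged, the configuration of this double bond decides between clear inhibition and none in this pair, since compound 3 gives 0% at the one dose tested, and the earlier compounds, both drawn E, could not show this. The whole step can be assigned to configuration because nothing else separates the pair: the fact that compounds 2 and 3 differ only in the configuration as drawn.

The compounds shown leave open how far this dependence on configuration extends, including whether it would hold with the ring of compound 1 in place of the ring of compound 2, or with an ester or an amide in place of the carboxylic acid, or with a longer chain. On these data alone, whether the step reflects inhibition at the target itself or some other process in the whole animal also stays open, as a single dose and a single time point cannot separate the two.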